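Tetrazole to carboxylic acid on the pyridine ring

A few compounds are considered here, and "the series" means these few. Any claim that something is new, unique, unknown or untested is made for them only; others in the source may bear on it.

In an assay on isolated protein for agonist activity at Bile acid receptor (Homo sapiens), read by FRET (a lower number here means that less compound is needed, a higher number that more compound is needed for the effect), compound 1 `O=C(O)c1cccc(C2CC2c2ccc(OCc3c(-c4c(Cl)cccc4Cl)noc3C3CC3)cc2Cl)c1` gives 32 nM, compound 2 `O=C(O)c1cncc(C2CC2c2ccc(OCc3c(-c4c(Cl)cccc4Cl)noc3C3CC3)cc2Cl)c1` gives 10 nM, and compound 3 `Clc1cc(OCc2c(-c3c(Cl)cccc3Cl)noc2C2CC2)ccc1C1CC1c1ccc(-c2nnn[nH]2)nc1` gives 131 nM. Compound 3 thus stands at the highest number of the three: a 4.1-fold higher number from compound 1 to compound 3 (0.61 log units; beyond the scatter) and a 13-fold higher number from compound 2 to compound 3 (1.12 log units; beyond the scatter). Between the two carboxylic acids, a 3.2-fold lower number from compound 1 to compound 2 (0.51 log units; beyond the scatter).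

Compound 4 `O=C(O)c1ccc(C2CC2c2ccc(OCc3c(-c4c(Cl)cccc4Cl)noc3C3CC3)cc2Cl)cn1` differs from compound 3 in one place: carboxy in place of 1H-tetrazol-5-yl on an aromatic carbon. Among the compounds with values here, the two measured steps that bear on this change both run from a carboxylic acid to the tetrazole, and both raise the number, the one from compound 1 modestly and the one from compound 2 by a large amount. Compound 4 carries the carboxy group on the same pyridine ring as compound 2, though on a different ring carbon, so the reverse move from compound 3 is expected to lower the number in this assay, and by a clear margin rather than within the scatter.

The step from compound 3 to compound 4 is therefore estimated at a 6.6-fold lower number from compound 3 to compound 4 (0.82 log units; beyond the scatter). For compound 4 in this assay the expected value is 20 nM, with a range from 6 nM to 70 nM.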

Compound 4, half-maximal effective concentration: 66 nM
The estimate for compound 4 lay 3.3-fold (0.52 log units) below the measured number; low and high end bracket the measured number.
By their numbers in this assay, from the lowest: compound 2; then compound 1; then compounds 4 and 3 (each within the scatter of the next).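

In this assay, carboxy and 1H-tetrazol-5-yl cannot be told apart on this aromatic carbon, next to the ring nitrogen and para to a large group (a 2.0-fold lower number from compound 3 to compound 4 (0.30 log units; within the scatter)). The placement of the carboxy group on the pyridine ring carries a clear difference of its own, as the change from 5-carboxypyridin-3-yl to 6-carboxypyridin-3-yl shows (a 6.6-fold higher number from compound 2 to compound 4 (0.82 log units; beyond the scatter)). Measured against the 3-carboxyphenyl of compound 1, 6-carboxypyridin-3-yl raises the number (a 2.1-fold higher number from compound 1 to compound 4 (0.31 log units; beyond the scatter)), while 5-carboxypyridin-3-yl lowers it, so the ring nitrogen does not shift the number in one direction across these compounds. Nothing at hand explains these differences.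

Going by these compounds, it remains open whether 1H-tetrazol-5-yl would match carboxy on the ring carbon that bears the acid in compound 2 as it does in compound 4. Also open, on these data alone, is how an amide or a methyl ester would compare with carboxy on either ring carbon.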